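Working notes: carboxyphenyl ether series, modulator potency

The source may report more compounds than this note shows. Statements on the series, on what has been measured and on what is new or still open speak of the compounds shown alone.

Measured so far:
- compound 1 `Cc1c(OC[C@@H](C)COc2ccc(F)c(C(=O)O)c2)ccc(C(=O)CC(C)(C)C)c1O`: 1180 nM
- compound 2 `Cc1c(OC[C@@H](C)COc2ccc(Cl)c(C(=O)O)c2)ccc(C(=O)CC(C)(C)C)c1O`: 2200 nM

Among the measured compounds shown here, in an assay for positive allosteric modulation of metabotropic glutamate receptor 3 (Rattus norvegicus) (on this read-out lower numbers stand for an effect already at smaller amounts and higher numbers for an effect only at larger amounts of compound), compound 2 gives the higher of the two numbers so far, and its only neighbour is compound 1; the step of a 1.9-fold higher number from compound 1 to compound 2 (0.27 log units; within the scatter) covers chloro in place of fluoro on an aromatic carbon and does not reach beyond the scatter.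

Compound 3 `Cc1cc(C(=O)O)ccc1OC[C@H](C)COc1ccc(C(=O)CC(C)(C)C)c(O)c1C` is not yet measured. It differs from compound 2 by 4-carboxy-2-methylphenyl in place of 3-carboxy-4-chlorophenyl on an oxygen on a saturated carbon, in words: 4-carboxy-2-methylphenyl in place of 3-carboxy-4-chlorophenyl on an oxygen on a saturated carbon. For the measured compounds named here, no measured step touches this change: the one step on hand, from compound 1 to compound 2, only swaps a halogen and stays within the scatter, so it gives no direction for moving the carboxy group and adding a methyl. The working expectation is therefore a number close to the present pair, with a wide range, and no step beyond the scatter is assumed; the step from compound 2 to compound 3 is estimated as a 1.2-fold lower number from compound 2 to compound 3 (0.09 log units; within the scatter). For compound 3 the estimate in this assay is 1800 nM, expected between 500 nM and 7000 nM.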

Compound 3, half-maximal effective concentration: 1520 nM
For compound 3 the middle estimate is 1.2-fold (0.07 log units) above the measured one, within the range that was stated.
By their numbers in this assay, from the lowest: compounds 1, 3 and 2 (each within the scatter of the next).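

Until now this position had only shown a halogen swap. It also accepts 4-carboxy-2-methylphenyl on an oxygen on a saturated carbon: in this assay the change gives a 1.4-fold lower number from compound 2 to compound 3 (0.16 log units; within the scatter) and a 1.3-fold higher number from compound 1 to compound 3 (0.11 log units; within the scatter). Among these three compounds, then, neither the halogen nor the arrangement of the carboxy group in 3-carboxy-4-chlorophenyl and 3-carboxy-4-fluorophenyl is needed to stay within the scatter. No measurement on hand accounts for this result.

From the compounds shown here alone, all three compounds carry a carboxy group on this aryl ring, so it remains open how an amide, a nitrile or a tetrazole in place of that carboxylic acid would read in this assay. Going by these compounds, the separate contributions of the moved carboxy group and the added methyl also remain open, as compound 3 changes both at once.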